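Propylamino in place of methylamino on compound 1

The source may hold more compounds than are shown below. What is called first, only, known or untested is meant among the compounds shown, and "the series" means these compounds.

Compound 1 `CNC(=O)[C@H]1O[C@@H](n2cnc3c(NC)nc(C#Cc4ccc(F)s4)nc32)[C@H](O)[C@@H]1O` gives 1510 nM in an assay on HEK293 cells for displacement of a labelled ligand from adenosine receptor A3 (Mus musculus) (a higher number here means a weaker inhibitor, a lower number a stronger inhibitor), the highest number among the three measured compounds. Compound 2 `CNC(=O)[C@@]12C[C@@H]1[C@@H](n1cnc3c(NC)cc(C#Cc4ccc(F)s4)nc31)[C@H](O)[C@@H]2O` gives 37 nM and compound 3 `CCNc1cc(C#Cc2ccc(F)s2)nc2c1ncn2[C@H]1[C@H](O)[C@H](O)[C@]2(C(=O)NC)C[C@H]12` gives 25 nM, both built on a different core from compound 1, so compound 1 stands well apart from either on the numbers alone. Compound 4 `CCCNc1nc(C#Cc2ccc(F)s2)nc2c1ncn2[C@@H]1O[C@H](C(=O)NC)[C@@H](O)[C@H]1O` differs from compound 1 only in ethyl in place of hydrogen on a saturated chain carbon bound to a nitrogen on an aromatic ring. Within the data shown here, the one measured step that bears on this is the change at the same place on the core of compound 2: a 1.5-fold lower number from compound 2 to compound 3 (0.17 log units; within the scatter). That step used a smaller group on another core and stayed within the scatter, so it supports only a modest expectation for a longer chain here, with no clear direction. For compound 4 the expected step is therefore a 1.3-fold lower number from compound 1 to compound 4 (0.10 log units; within the scatter), small and uncertain. Compound 4 is estimated at 1200 nM, with a range of 400 nM to 3500 nM.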

Compound 4, inhibition constant: 435 nM
For compound 4 the middle estimate is 2.8-fold (0.44 log units) above the measured one, and the stated range covers the measured number.
By their numbers in this assay, from the lowest: compounds 3 and 2 (each within the scatter of the next); then compound 4; then compound 1.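

In this assay, among these compounds, the change from methylamino to propylamino on the core of compound 1 gives a 3.5-fold lower number from compound 1 to compound 4 (0.54 log units; beyond the scatter) and is the only step at this place that lies beyond the scatter. Among the compounds shown here, the one earlier step at this place, a 1.5-fold lower number from compound 2 to compound 3 (0.17 log units; within the scatter), stayed within the scatter, so the new result shows that the number can respond to ethyl in place of hydrogen here, although the two steps differ in both core and group and cannot be separated. Nothing available explains the step on the core of compound 1.

From the compounds shown here alone, whether butylamino or a longer chain extends the step on this core, and where ethylamino falls, remains open. Also open, going by these compounds, is whether propylamino on the core of compound 2 would give a step of similar size.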